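The source may report more compounds than this note shows. Statements on the series, on what has been measured and on what is new or still open speak of the compounds shown alone.

Series in an ADME assay on HEL cells (Homo sapiens) for cytotoxicity; on this read-out lower numbers stand for higher toxicity in this test and higher numbers for lower toxicity in this test:
- compound 1 `O=C(COc1cccc2ccccc12)N/N=C/c1ccccc1Br`: 100 ug/mL
- compound 2 `O=C(COc1cccc2ccccc12)N/N=C/C=C/c1ccccc1`: 100 ug/mL
- compound 3 `C/C(=N\NC(=O)COc1cccc2ccccc12)c1ccccc1O`: 4 ug/mL

Compound 1 sits level with compound 2 at 100 ug/mL, and the two share the highest of the three numbers. Compound 3 gives a much lower number, 4 ug/mL.

The next compound to read is compound 4 `O=C(COc1cccc2ccccc12)N/N=C/c1ccccc1Cl`, which has 2-chlorophenyl in place of 2-phenylethenyl on a carbon with a double bond to nitrogen.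

Going by the values given here, one measured step bears directly on this change: no change at the digits printed from compound 1 to compound 2 (within the scatter). That step swaps 2-bromophenyl for 2-phenylethenyl at the same place and shows no size beyond the scatter. The change to compound 4 runs nearly the reverse way, ending in 2-chlorophenyl rather than 2-bromophenyl. Among the compounds with values here, no measured pair in this set isolates a swap between those two groups, so the match with compound 1 is only an analogy.

No step beyond the scatter is therefore expected in this assay. The estimated change is a 1.3-fold lower number from compound 2 to compound 4 (0.10 log units; within the scatter). The range is left wider on the low side, since compound 3 at 4 ug/mL shows that much lower numbers occur in this set.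

For compound 4 the expected value is 80 ug/mL, with an estimated range of 20 ug/mL to 120 ug/mL.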

Compound 4, half-maximal cytotoxic concentration: 62.7 ug/mL
The estimate for compound 4 lay 1.3-fold (0.11 log units) above the measured number, and the stated range covers the measured number.
By their numbers in this assay, from the lowest: compound 3; then compounds 4, 1 and 2 (each within the scatter of the next).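

In this assay the place on a carbon with a double bond to nitrogen now carries a third group, 2-chlorophenyl, and the swap from 2-phenylethenyl gives a 1.6-fold lower number from compound 2 to compound 4 (0.20 log units; within the scatter) with no step beyond the scatter. The series also gains its first direct reading of a halogen swap on the aromatic ring, chloro in place of bromo on an aromatic carbon, which gives a 1.6-fold lower number from compound 1 to compound 4 (0.20 log units; within the scatter) and likewise stays within the scatter. So 2-bromophenyl, 2-chlorophenyl and 2-phenylethenyl all read alike at this place in this test, and no measurement at hand offers an explanation for the small differences among them.

Compound 3, at 4 ug/mL, differs from the other compounds in more than one place, so its low number cannot be tied to either the hydroxy group on its phenyl ring or the methyl on the carbon with a double bond to nitrogen. Also open, going by these compounds, is whether a phenyl ring carrying an amine or a carboxylic acid, or a saturated alkyl chain in place of the ring, would keep the number in the range of the halogen-bearing compounds.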